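Swapping chloro for trifluoromethyl on the shared core

The source may report more compounds than this note shows. Statements on the series, on what has been measured and on what is new or still open speak of the compounds shown alone.

Measured so far:
compound 1 `N=C(N)c1ccc(Nc2nc3cc(Cl)ccc3[nH]2)cc1` gives 46400 nM
compound 2 `CC(C)CNC(=N)c1ccc(Nc2nc3cc(C(=N)NCC(C)C)ccc3[nH]2)cc1` gives 84400 nM
compound 3 `Cc1cc2[nH]c(Nc3ccc(C(=N)N)cc3)nc2cc1Cl` gives 23300 nM

These values come from an ADME assay on L6 cells (Rattus norvegicus) for cytotoxicity, read by resazurin assay (on this read-out higher numbers stand for weaker inhibition and lower numbers for stronger inhibition), where compound 1 lies within the scatter of both compound 2 and compound 3. Compound 4 `N=C(N)c1ccc(Nc2nc3cc(C(F)(F)F)ccc3[nH]2)cc1` has not yet been measured. It carries trifluoromethyl in place of chloro on an aromatic carbon of a six-membered aromatic ring of carbon only: trifluoromethyl in place of chloro on an aromatic carbon. For the measured compounds named here, no measured compound carries trifluoromethyl, so the data offer no direct comparison. Going by the values given here, only one measured step alters a single substituent on the shared core: a 2.0-fold lower number from compound 1 to compound 3 (0.30 log units; within the scatter). That is a different change, since the chloro stays in place, but it is the nearest guide available. Among the compounds with values here, compound 2 differs from compound 1 in more than one place and gives no such step. A step beyond the scatter is therefore not expected in this assay, and no direction is favoured with any confidence. The expected step is a 1.2-fold lower number from compound 1 to compound 4 (0.09 log units; within the scatter). For compound 4 the estimated value is 38000 nM, with an expected range from 15000 nM to 90000 nM.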

Compound 4, half-maximal inhibitory concentration: 41400 nM
For compound 4 the middle estimate is 1.1-fold (0.04 log units) below the measured one, and the stated range covers the measured number.
By their numbers in this assay, from the lowest: compounds 3, 4, 1 and 2 (each within the scatter of the next, the first and the last beyond it).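

In this assay, for the compounds shown here, the step of a 1.1-fold lower number from compound 1 to compound 4 (0.05 log units; within the scatter) is the first on this aromatic carbon that replaces the chloro itself, since the earlier step on the shared core kept the chloro in place. The exchange puts trifluoromethyl, with 4 heavy atoms, where chloro had 1 heavy atom, and the two numbers still stay within the scatter of each other, so in this read-out the chloro is not needed at this place. Nothing at hand explains why this exchange leaves the number so little moved.

Going by these compounds, it remains open whether an amine, a carboxylic acid or a longer alkyl chain on this aromatic carbon would also stay within the scatter. Also open, on these data alone, is how trifluoromethyl would read alongside the methyl of compound 3.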